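From 1-aminoethyl to 1-amino-3-methylbutyl on the carbonyl

This account rests on a few compounds, and the source may have more. Where it says the series, first, only, none or still open, it means among the compounds named here.

For the measured compounds named here, in a physicochemical assay for solubility (a higher number here means a more soluble compound, a lower number a less soluble compound), compound 1 `C[C@H]1[C@H](N)CN1c1nc2c(cc1F)c(=O)c(C(=O)O)cn2C1CC1` gives 23 ug/mL and compound 2 `C[C@@H](N)C(=O)N[C@@H]1CN(c2nc3c(cc2F)c(=O)c(C(=O)O)cn3C2CC2)[C@H]1C` gives 495 ug/mL, the higher of the two numbers so far. Going by the values given here, the only measured step, a 22-fold higher number from compound 1 to compound 2 (1.33 log units; beyond the scatter), puts (1-aminoethyl)carbonyl in place of hydrogen on an amine nitrogen. It is large and beyond the scatter.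

Compound 3 `CC(C)C[C@H](N)C(=O)N[C@@H]1CN(c2nc3c(cc2F)c(=O)c(C(=O)O)cn3C2CC2)[C@H]1C` keeps the carbonyl and alters the group on it: 1-amino-3-methylbutyl in place of 1-aminoethyl on a carbonyl carbon. In words, 1-amino-3-methylbutyl stands in place of 1-aminoethyl on a carbonyl carbon.

The measured step bears on this change only in part. Among the compounds with values here, it adds the whole group to the amine nitrogen, and no measured pair varies the chain itself. The starting point is therefore compound 2 at 495 ug/mL. A much smaller move than the measured step seems likely, and the downward direction is a tentative judgement with no measured support. The expected change is a 2.0-fold lower number from compound 2 to compound 3 (0.30 log units; within the scatter). For compound 3 the estimated value is 250 ug/mL, with an expected range of 80 ug/mL to 700 ug/mL.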

Compound 3, solubility: > 500 ug/mL
Compound 3 was reported as a limit; the forecaster's own chance of this, stated with the estimate: 5%; at least 2.0-fold (0.30 log units) between middle value and limit.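

In this assay compound 3 gives > 500 ug/mL, which is a limit and not a number. The step with 1-amino-3-methylbutyl in place of 1-aminoethyl on this carbonyl carbon can be read for direction only, a number no lower from compound 2 to compound 3 (the limit leaves the size open), and its size cannot be read because the value sits at the limit of the assay: the limit of > 500 ug/mL in this assay, at which 1 of the 3 values shown sits. Against the unsubstituted amine, the second group on this amine nitrogen also gives a large step, an at least 21-fold higher number from compound 1 to compound 3 (1.33 log units; beyond the scatter), so both compounds carrying a group here stand well clear of compound 1, and the longer of the two chains shown does not bring the value back down.

Still open, going by these compounds, is whether 1-amino-3-methylbutyl and 1-aminoethyl differ at all on this carbonyl carbon in this assay, since the limit hides any gap between them. Also open, on these data alone, is how a longer chain, or a carboxylic acid in place of the amine on the chain, would read in this assay.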